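A Ring Substituent Swap on Compound 3

The source may report more compounds than this note shows. Statements on the series, on what has been measured and on what is new or still open speak of the compounds shown alone.

In an ADME assay on the whole organism (Rattus norvegicus, strain Sprague-Dawley) for pharmacokinetics, using cassette dosing, at a dose of 1 mg/kg by the oral route (on this read-out higher numbers stand for higher oral bioavailability and lower numbers for lower oral bioavailability), compound 1 `O=C(c1cc(-c2cn[nH]c2)on1)N1CCC(Cc2ccc(Cl)cc2)CC1` gives 0.6%, compound 2 `O=C(c1cc(-c2ccc(=O)[nH]c2)on1)N1CCC(Cc2ccc(F)cc2)CC1` gives 18.4% and compound 3 `O=C(Nc1ccc2[nH]c(=O)oc2c1)C(=O)N1CCN(c2ccc(Cl)cc2)CC1` gives 17.8%. Compound 3 thus sits level with compound 2 within the scatter, and beyond the scatter above compound 1. Compound 4 `COc1ccc(N2CCN(C(=O)C(=O)Nc3ccc4[nH]c(=O)oc4c3)CC2)cc1F` differs from compound 3 by carrying 3-fluoro-4-methoxyphenyl in place of 4-chlorophenyl on an amine nitrogen in a ring. Among the measured compounds shown here, no measured pair of compounds shows a change of this kind, so the expectation remains loose. The expected step in this assay is small, a number 2.8 percentage points lower from compound 3 to compound 4 (within the scatter), a slight fall that stays within the scatter. For compound 4 the estimated value is 15%, with an expected range of 4% to 30%.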

Compound 4, oral bioavailability: 0.6%
For compound 4 the middle estimate is 14.4 percentage points above the measured one; measured number outside the range, below it.
By their numbers in this assay, from the lowest: compounds 1 and 4 (each within the scatter of the next); then compounds 3 and 2 (each within the scatter of the next).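

At this amine nitrogen in a ring, the choice of aryl group matters in this assay: 3-fluoro-4-methoxyphenyl in place of 4-chlorophenyl gives a number 17.2 percentage points lower from compound 3 to compound 4 (beyond the scatter), with the rest of the molecule unchanged. Among the compounds shown here, this is the first measured pair to show that this position is not indifferent to such a swap. Nothing at hand accounts for the fall. The entering group differs from the leaving one in more than one substituent, and the compounds shown do not separate the part played by the fluorine from that of the methoxy. Going by these compounds, how a plain phenyl or a pyridine ring would fare at this place also remains open.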